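Benzoyl for Acetyl on a Second Core

The source may report more compounds than this note shows. Statements on the series, on what has been measured and on what is new or still open speak of the compounds shown alone.

Measured compounds:
Compound 1, `CC(=O)OC/C(=C\c1ccccc1[N+](=O)[O-])C(=O)c1ccccc1`: 18000 nM
Compound 2, `O=C(OC/C(=C\c1ccccc1[N+](=O)[O-])C(=O)c1ccccc1)c1ccccc1`: 18000 nM
Compound 3, `CC(=O)OC/C(=C/c1ccc(Cl)cc1Cl)C(=O)c1ccccc1`: 19000 nM

All three were tested in a functional assay on WiDr cells (Homo sapiens) for inhibition, read by sulforhodamine B assay, with a stated time of 48 h; a lower number here means a stronger inhibitor of growth, a higher number a weaker inhibitor of growth. Compound 1 and compound 2 share a core and differ in one place: phenyl in place of methyl on a carbonyl carbon. That change made no change at the digits printed from compound 1 to compound 2 (within the scatter), so in this assay the larger ester group gave no gain and no loss.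

Compound 3 has a different core; the difference between the two cores is not broken down here. Its value in this assay sits close to that of compound 1 and compound 2, and the gaps among the three are within the scatter, so none of them can be called stronger or weaker than the others.

Compound 4, `O=C(OC/C(=C/c1ccc(Cl)cc1Cl)C(=O)c1ccccc1)c1ccccc1`, is not yet measured. It stands to compound 3 as compound 2 stands to compound 1: phenyl in place of methyl on a carbonyl carbon. The place of the change is described in the same words for both pairs, so this is the same change on a second core. Because no change at the digits printed from compound 1 to compound 2 (within the scatter), the expectation is that the step from compound 3 to compound 4 will also be small, estimated as no change at the digits printed from compound 3 to compound 4 (within the scatter). Compound 4 is therefore expected to give about 19000 nM, estimated to lie between 9000 nM and 40000 nM.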

Compound 4, concentration for 50% growth inhibition: 8700 nM
The estimate for compound 4 lay 2.2-fold (0.34 log units) above the measured number; the whole stated range lies above it.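

In this assay, putting benzoyl in place of acetyl on the core of compound 3 gave a 2.2-fold lower number from compound 3 to compound 4 (0.34 log units; beyond the scatter), a modest gain in growth inhibition on this core. The same change on the core of compound 1 moved nothing, yet the two steps cannot be told apart, so the data give no sign that the change behaves differently on the two cores: the same change on two cores in this assay, no change at the digits printed (within the scatter) from compound 1 to compound 2 and a 2.2-fold lower number (0.34 log units; beyond the scatter) from compound 3 to compound 4, 2.2-fold (0.34 log units) apart, within the scatter of two such steps This does not show that the core of compound 3 responds more strongly to the change than the core of compound 1, and two pairs cannot show how the change would behave on any other core in the series or why the number moved.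

The compounds shown carry only methyl or phenyl on this carbonyl carbon, so it remains open what a longer chain such as butyl, or a phenyl ring bearing an amine or a carboxylic acid, would do. Also open, on these data alone, is how an amide in place of the ester would read in this assay.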